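The compounds below may be only part of what the source reports. "The series", "measured", "known", "first", "only" and "open" are said of these compounds alone.

Series notes. Compound 1 `Clc1ccc2[nH]c(-c3cn(-c4ccccc4)nc3-c3ccccc3)nc2c1` gives 1960 nM in a functional assay on MCF7 cells (Homo sapiens) for antiproliferative activity, read by MTT assay, with a stated time of 48 h; on this read-out lower numbers stand for stronger inhibition and higher numbers for weaker inhibition. Compound 2 `COc1ccc2[nH]c(-c3cn(-c4ccccc4)nc3-c3ccccc3)nc2c1` gives 1590 nM; the change methoxy in place of chloro on an aromatic carbon made a 1.2-fold lower number from compound 1 to compound 2 (0.09 log units; within the scatter). Compound 3 `Fc1ccc2[nH]c(-c3cn(-c4ccccc4)nc3-c3ccc(Cl)cc3)nc2c1` gives 2830 nM; the difference between the core of compound 3 and the core of compound 1 is not broken down here. Compound 4 `COc1ccc(-c2nn(-c3ccccc3)cc2-c2nc3cc(F)ccc3[nH]2)cc1` awaits measurement; it differs from compound 3 by methoxy in place of chloro on an aromatic carbon. This is the same kind of change as from compound 1 to compound 2, not the same: there the methoxy stood on a ring that is part of a fused or bridged system of two rings, meta to a fused ring and para to a fused ring; here it stands on a six-membered aromatic ring of carbon only, para to a large group. Since the earlier step of a 1.2-fold lower number from compound 1 to compound 2 (0.09 log units; within the scatter) stayed within the scatter, a small step is expected for compound 4 as well, a 1.2-fold lower number from compound 3 to compound 4 (0.09 log units; within the scatter). Compound 4 is estimated at 2300 nM, between 1100 nM and 5000 nM.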

Compound 4, half-maximal inhibitory concentration: 1510 nM
For compound 4 the middle estimate is 1.5-fold (0.18 log units) above the measured one; the measured number falls inside the stated range.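

Methoxy in place of chloro, here 4-chlorophenyl to 4-methoxyphenyl, gives a 1.9-fold lower number from compound 3 to compound 4 (0.27 log units; within the scatter) in this assay. Set beside the earlier step, the change reads alike on the two cores: the same change on two cores in this assay, a 1.2-fold lower number (0.09 log units; within the scatter) from compound 1 to compound 2 and a 1.9-fold lower number (0.27 log units; within the scatter) from compound 3 to compound 4, 1.5-fold (0.18 log units) apart, within the scatter of two such steps. This does not show that the change carries to other cores in this series, since it rests on two pairs, with the methoxy on a different ring in each, and both steps stay within the scatter.

Still open, on these data alone, is whether an amine or a carboxylic acid on that aromatic carbon, para to a large group, would give a step beyond the scatter. Also open, as far as these compounds go, is how the same change would read on a core carrying a longer alkoxy chain.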